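A few compounds are considered here, and "the series" means these few. Any claim that something is new, unique, unknown or untested is made for them only; others in the source may bear on it.

Compound 1, with structure `COC(=O)c1cc(=O)c2c(OC)cc(OC)cc2[nH]1`, and compound 2, with structure `COc1ccc(-c2cc(=O)c3c(OC)cc(OC)cc3n2S(=O)(=O)c2ccc([N+](=O)[O-])cc2)cc1`, share the same core and were both tested in a functional assay on HepG2 cells (Homo sapiens) for antiproliferative activity, with a stated time of 72 h; a higher number here means that more compound is needed for the effect, a lower number that less compound is needed. In this assay compound 1 gives > 34400 nM, which is a limit of the assay rather than a measured number. In this assay compound 2 gives > 29300 nM, again a limit and not a number. For the measured compounds named here, compound 2 thus stands at the limit of > 29300 nM in this assay, at which 1 of the 2 values shown sits, while compound 1 stands at the limit of > 34400 nM in this assay, at which 1 of the 2 values shown sits; the two values show only that neither compound reached a measurable effect. Compound 3, with structure `COc1ccc(-c2cc(=O)c3c(OC)cc(OC)cc3n2S(=O)(=O)c2c(F)c(F)c(F)c(F)c2F)cc1`, differs from compound 2 in one place: 2,3,4,5,6-pentafluorophenyl in place of 4-nitrophenyl on a sulfonyl sulfur. Going by the values given here, no step between two measured compounds is available to size such a change, so the direction cannot be read from the data. Starting from a limit, the expected step that the limit leaves unreadable from compound 2 to compound 3 is taken as none beyond the usual scatter. Compound 3 is therefore expected to give about 40000 nM in this assay, in a range from 10000 nM to 120000 nM, with a good chance that again only a limit is reported.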

Compound 3, half-maximal effective concentration: > 34400 nM
Compound 3 ended at the assay's limit; the forecaster's own chance of this, stated with the estimate: 75%; the middle value lies beyond the limit too.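

For the compounds shown here, compound 2 and compound 3 both end at a limit in this assay, so putting 2,3,4,5,6-pentafluorophenyl in place of 4-nitrophenyl on the sulfonyl sulfur gives no step that can be read. The compounds shown leave open whether any group at this place can give a measurable antiproliferative effect.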